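The compounds below may be only part of what the source reports. "The series", "measured", "known", "first", "only" and "open" are said of these compounds alone.

Measured in an assay on membranes from uterus for displacement of a labelled ligand from Angiotensin type II receptor (Sus scrofa), with a stated time of 1.5 h; a lower number here means a stronger inhibitor, a higher number a weaker inhibitor:
Compound 1 `CCCCOC(=O)NS(=O)(=O)c1sc(CC(C)C)cc1-c1ccc(CN2C(=O)CN(C)C2=O)cc1`: 68.6 nM
Compound 2 `CCCCOC(=O)NS(=O)(=O)c1sc(CC(C)C)cc1-c1ccc(Cc2ncco2)cc1`: 3.9 nM
Compound 3 `CCCCOC(=O)NS(=O)(=O)c1sc(CC(C)C)cc1-c1ccc(CN2CCCC2=O)cc1`: 3.5 nM

Among these three, compound 3 gives the lowest number in this assay, with compound 2 close by and compound 1 far off: the gap a 1.1-fold lower number from compound 2 to compound 3 (0.05 log units; within the scatter) is within the scatter, while a 20-fold lower number from compound 1 to compound 3 (1.29 log units; beyond the scatter) is large. Compound 4 `CCCCOC(=O)NS(=O)(=O)c1sc(CC(C)C)cc1-c1ccc(CN2C(=O)N(C)C(C)(C)C2=O)cc1` is still unmeasured. It differs from compound 3 in one place: 3,4,4-trimethyl-2,5-dioxoimidazolidin-1-yl in place of 2-oxopyrrolidin-1-yl on a saturated chain carbon bound to an aromatic carbon. The group that enters is a close relative of the group carried by compound 1, adding two methyls on the ring carbon. The step that bears on it is therefore a 20-fold lower number from compound 1 to compound 3 (1.29 log units; beyond the scatter), which runs the opposite way, and an 18-fold lower number from compound 1 to compound 2 (1.25 log units; beyond the scatter) points the same way. Going from compound 3 to compound 4 is expected to reverse that large drop, giving a clearly higher number in this assay, roughly a 13-fold higher number from compound 3 to compound 4 (1.11 log units; beyond the scatter). For compound 4 the estimate in this assay is 45 nM, with a range from 12 nM to 150 nM.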

Compound 4, inhibition constant: 3.6 nM
Beside the measured number, compound 4's estimate is 13-fold (1.10 log units) above it; measured number below the stated range.
By their numbers in this assay, from the lowest: compounds 3, 4 and 2 (each within the scatter of the next); then compound 1.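

In this assay the large step of a 19-fold lower number from compound 1 to compound 4 (1.28 log units; beyond the scatter) comes with only two extra methyls, the change from 3-methyl-2,5-dioxoimidazolidin-1-yl to 3,4,4-trimethyl-2,5-dioxoimidazolidin-1-yl, so the weak number of compound 1 does not hold for this ring type as a whole. The step of a 1.0-fold higher number from compound 3 to compound 4 (0.01 log units; within the scatter) and the step of a 1.1-fold lower number from compound 2 to compound 4 (0.03 log units; within the scatter) both lie within the scatter, so three quite different groups on this saturated chain carbon give matching numbers, and compound 1 alone goes against that. Nothing measured here tells why two methyls go with so large a step.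

Open, going by these compounds, is whether a single added methyl would already close the gap. Also open, on these data alone, is whether an amine or a carboxylic acid on the same saturated chain carbon would keep the number this low.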